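Swapping the dichlorophenyl ketone aryl for a dimethoxyphenyl

A few compounds are considered here, and "the series" means these few. Any claim that something is new, unique, unknown or untested is made for them only; others in the source may bear on it.

The measured compounds and their values:
compound 1, `COc1cc(-c2cc(/C=C/C(=O)c3ccc(Cl)c(Cl)c3)[nH]n2)cc(OC)c1OC`, -24%
compound 2, `COc1ccc(-c2cc(/C=C/C(=O)c3ccc(N)cc3)[nH]n2)cc1OC`, -76%
compound 3, `COc1ccc(-c2cc(/C=C/C(=O)c3cc(OC)c(OC)c(OC)c3)[nH]n2)cc1OC`, -60%

In a functional assay on NCI-H460 cells (Homo sapiens) for cytotoxicity, read by sulforhodamine B assay, with a stated time of 48 h, tested at 100 uM (a higher number here means a weaker effect of the compound at the concentration tested, a lower number a stronger effect), compound 1 stands highest of the three numbers. Compound 3 lies nearest, a number well beyond the scatter lower, and compound 2 lies furthest, lower still and also beyond the scatter. The structural step to compound 4, `COc1ccc(C(=O)/C=C/c2cc(-c3cc(OC)c(OC)c(OC)c3)n[nH]2)cc1OC`, is the following change: 3,4-dimethoxyphenyl in place of 3,4-dichlorophenyl on a carbonyl carbon. Going by the values given here, no step between two measured compounds isolates this change, so its size is not known directly. Since compound 2, which carries an amino-bearing aryl on the carbonyl side, gives -76%, and compound 3, which carries a methoxy-bearing aryl on the carbonyl side, gives -60%, a step lower, beyond the scatter, is expected in this assay. The estimated step is a number 31 percentage points lower from compound 1 to compound 4 (beyond the scatter). Compound 4 is thus expected to give -55%, in the range -80% to -25%.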

Compound 4, a percentage reported as activity, at one concentration (the size of the read-out at that concentration, not a potency): -65%
For compound 4 the middle estimate is 10 percentage points above the measured one; the range from low to high includes it.
By their numbers in this assay, from the lowest: compound 2; then compounds 4 and 3 (each within the scatter of the next); then compound 1.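

The change from 3,4-dichlorophenyl to 3,4-dimethoxyphenyl on a carbonyl carbon can now be read directly in this assay, giving a number 41 percentage points lower from compound 1 to compound 4 (beyond the scatter). This shows that the aryl at this position alone, with the rest of compound 1 unchanged, can shift the read-out towards a stronger effect at the concentration tested. Nothing at hand accounts for the size of this step. Still open, going by these compounds, is whether the step would persist on a different core, and how an unsubstituted phenyl or a carboxylic acid on this aryl would read.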